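A 2-phenylethenyl ester in place of a 3-methoxyphenyl ester

The source may hold more compounds than are shown below. What is called first, only, known or untested is meant among the compounds shown, and "the series" means these compounds.

Compound 1 `CC(=O)O[C@@H]1C=CC(=O)O[C@@H]1[C@@H](COC(=O)c1ccccc1)OC(C)=O` gives only the assay limit > 100000 nM in a functional assay on MRC5 cells (Homo sapiens) for inhibition, read by MTT assay, with a stated time of 72 h; a lower number here means a stronger inhibitor, a higher number a weaker inhibitor. Compound 2 `CC(=O)O[C@@H]1C=CC(=O)O[C@@H]1[C@@H](COC(=O)c1c(Cl)cc(Cl)cc1Cl)OC(C)=O` gives 45700 nM in this assay. Compound 3 `COc1cccc(C(=O)OC[C@@H](OC(C)=O)[C@H]2OC(=O)C=C[C@H]2OC(C)=O)c1` gives 91300 nM in this assay.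

All three share one core and differ only in the group on the carbonyl carbon of the ester. As far as these compounds go, compound 3 and compound 2 give numbers that lie within the scatter of each other, as the step of a 2.0-fold higher number from compound 2 to compound 3 (0.30 log units; within the scatter) shows; compound 1 gives only a limit, so its true number is unknown (the limit of > 100000 nM in this assay, at which 1 of the 3 values shown sits). The step of an at least 2.1-fold lower number from compound 1 to compound 2 (0.34 log units; beyond the scatter) is the only one beyond the scatter, and the step of an at least 1.0-fold lower number from compound 1 to compound 3 (0.03 log units; that floor lies within the scatter) sits at a floor within the scatter.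

Compound 4 `CC(=O)O[C@@H]1C=CC(=O)O[C@@H]1[C@@H](COC(=O)/C=C/c1ccccc1)OC(C)=O` is the next change at the same place: 2-phenylethenyl in place of 3-methoxyphenyl on a carbonyl carbon. Going by the values given here, the one measured exchange at this carbon, from compound 2 to compound 3, stayed within the scatter, so no step beyond the scatter is expected in this assay. Compound 4 is therefore estimated to give 100000 nM (range 30000 nM to 300000 nM). That estimate means an expected step of a 1.1-fold higher number from compound 3 to compound 4 (0.04 log units; within the scatter).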

Compound 4, half-maximal inhibitory concentration: > 100000 nM
Compound 4: a limit, no number; the forecaster's own chance of this, stated with the estimate: 45%; the middle value lies on the limit itself.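

Compound 4 is the second compound to reach the assay limit: the limit of > 100000 nM in this assay, at which 2 of the 4 values shown sit. Placing 2-phenylethenyl on the carbonyl carbon gives an at least 2.1-fold higher number from compound 2 to compound 4 (0.34 log units; beyond the scatter) in this assay, so this ester separates from the 2,4,6-trichlorophenyl ester, whereas an at least 1.0-fold higher number from compound 3 to compound 4 (0.03 log units; that floor lies within the scatter) means that it cannot be told apart from the 3-methoxyphenyl ester at that floor. The step between compound 1 and compound 4 cannot be read, as both give only limits.

As far as these compounds go, it remains open whether any group at this carbon can bring the number far below those seen so far, since all four compounds sit at high values. A 2-phenylethyl ester would test the double bond itself, and an amine or a carboxylic acid on the phenyl ring would test quite different substituents.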